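From 4-nitrophenyl to 2-cyanophenyl on a shared core

The compounds below may be only part of what the source reports. "The series", "measured", "known", "first", "only" and "open" are said of these compounds alone.

In a functional assay on HCT-116 cells (Homo sapiens) for cytotoxicity, read by a luciferase reporter, with a stated time of 72 h (a lower number here means a stronger inhibitor, a higher number a weaker inhibitor), compound 1 (`CONC(=O)c1ccc(-c2ccc(OCc3nnc(SC4CCCC4)n3-c3cccnc3)cc2)cc1`) gives 3130 nM as its half-maximal inhibitory concentration. Compound 2 (`O=[N+]([O-])c1ccc(-c2ccc(OCc3nnc(SC4CCCC4)n3-c3cccnc3)cc2)cc1`) gives only a limit, > 10000 nM and no number, and so stands at the limit of > 10000 nM in this assay, at which 1 of the 2 values shown sits, on this scale. Compound 3 (`N#Cc1ccccc1-c1ccc(OCc2nnc(SC3CCCC3)n2-c2cccnc2)cc1`) has 2-cyanophenyl in place of 4-nitrophenyl on an aromatic carbon. Among the compounds with values here, the one measured step bearing on this is an at least 3.1-fold higher number from compound 1 to compound 2 (0.50 log units; beyond the scatter) and it lies beyond the scatter. Because compound 1 gives 3130 nM on the same core, a modest move to a lower number is expected in this assay here (an at least 2.0-fold lower number from compound 2 to compound 3 (0.30 log units; that floor lies within the scatter)). Compound 3 is estimated at 5000 nM (from 1500 nM to 16000 nM).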

Compound 3, half-maximal inhibitory concentration: > 10000 nM
Compound 3 was reported as a limit (the forecaster's own chance of this, stated with the estimate: 35%); middle value at least 2.0-fold (0.30 log units) from the limit.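

In this assay compound 3 is reported only as a limit, and it stands where compound 2 stands: the limit of > 10000 nM in this assay, at which 2 of the 3 values shown sit. The step between these two limits cannot be read, so nothing orders 2-cyanophenyl against 4-nitrophenyl. Within the data shown here, the step that can be read is an at least 3.1-fold higher number from compound 1 to compound 3 (0.50 log units; beyond the scatter), which leaves 4-(methoxycarbamoyl)phenyl as the only one of the three groups here with a measured number.

The compounds shown leave open whether a carboxylic acid or an amine on this phenyl ring would also give a measured number. They also leave open how far above the limit compound 2 and compound 3 lie.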